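Benzyl for butyl on the core nitrogen of compound 2

A few compounds are considered here, and "the series" means these few. Any claim that something is new, unique, unknown or untested is made for them only; others in the source may bear on it.

Three compounds have numbers in a functional assay on HCT-116 cells (Homo sapiens) for antiproliferative activity, read by CCK-8 assay, with a stated time of 72 h, tested at 8 uM; a higher number here means a stronger effect of the compound at the concentration tested, a lower number a weaker effect. Compound 1 `Cc1ccc(Nc2nc(Cl)nc3c2ncn3Cc2ccc(/C=C/C(=O)Nc3ccccc3N)cc2)cc1` gives 15%, compound 2 `CCCCn1cnc2c(NCc3ccc(C(=O)Nc4ccccc4N)cc3)nc(Cl)nc21` gives 40.9%, and compound 3 `CCCCn1cnc2c(Nc3ccccc3)nc(NCOCc3ccc(/C=C/C(=O)Nc4ccccc4N)cc3)nc21` gives 51.9%. Compound 2 stands second highest of the three: compound 3 is the nearest, higher by a gap beyond the scatter, and compound 1 the furthest, lower by a gap beyond the scatter. Compound 4 `Nc1ccccc1NC(=O)c1ccc(CNc2nc(Cl)nc3c2ncn3Cc2ccccc2)cc1` has not yet been measured in this assay. It differs from compound 2 in one place: phenyl in place of propyl on a saturated chain carbon bound to an aromatic nitrogen. For the measured compounds named here, no measured pair shows this change on its own, so the direction is open; a step of modest size is expected, most likely none beyond the scatter, with the risk leaning downward. Compound 4 is expected to give 35%, within 15% to 55%, a step of a number 5.9 percentage points lower from compound 2 to compound 4 (within the scatter) that is estimated, not measured.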

Compound 4, a percentage reported as inhibition, at one concentration (the size of the read-out at that concentration, not a potency): 11.5%
Compound 4: the middle estimate sits 23.5 percentage points above what was measured; the measured number lies below the stated range.
By their numbers in this assay, from the lowest: compounds 4 and 1 (each within the scatter of the next); then compound 2; then compound 3.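

For the compounds shown here, the group on the core nitrogen is not a silent position in this assay: butyl to benzyl gives a number 29.4 percentage points lower from compound 2 to compound 4 (beyond the scatter) as the first single-place step. The reading rests on this one pair and holds for the background of compound 2 only. Nothing at hand accounts for the drop.

From the compounds shown here alone, whether the loss follows the aromatic ring or the larger group stays open, and a cyclohexylmethyl group or a hexyl chain at this place would separate the two. Going by these compounds, whether the same change costs as much on the other compounds' backgrounds also remains open.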